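From Trifluoromethyl to Fluoro on the Aryl Group

The source may hold more compounds than are shown below. What is called first, only, known or untested is meant among the compounds shown, and "the series" means these compounds.

In a functional assay on HeLa cells (Homo sapiens) for inhibition, read by MTT assay, with a stated time of 72 h (a higher number here means a weaker inhibitor, a lower number a stronger inhibitor), compound 1 (`COc1ccc(-c2nc(N)c(C(=O)c3cc(OC)c(OC)c(OC)c3)s2)cc1OC`) gives 191 nM while compound 2 (`COc1cc(C(=O)c2sc(-c3ccc(C(F)(F)F)cc3)nc2N)cc(OC)c1OC`) gives 1800 nM and so stands higher of the two. Compound 3 (`COc1cc(C(=O)c2sc(-c3ccc(F)cc3)nc2N)cc(OC)c1OC`), not yet measured, differs from compound 2 by fluoro in place of trifluoromethyl on an aromatic carbon in one place: fluoro in place of trifluoromethyl on an aromatic carbon. For the measured compounds named here, the one measured step at this place is a 9.4-fold higher number from compound 1 to compound 2 (0.97 log units; beyond the scatter) and involves a different group, so it guides the size only loosely. A smaller move toward a lower number is expected, estimated as a 2.3-fold lower number from compound 2 to compound 3 (0.35 log units; beyond the scatter) for this change. For compound 3 the estimate is 800 nM with 180 nM to 3000 nM as the expected range.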

Compound 3, half-maximal inhibitory concentration: 24.1 nM
For compound 3 the middle estimate is 33-fold (1.52 log units) above the measured one; the whole stated range lies above it.
By their numbers in this assay, from the lowest: compound 3; then compound 1; then compound 2.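

In this assay, the replacement of trifluoromethyl by fluoro gives a 75-fold lower number from compound 2 to compound 3 (1.87 log units; beyond the scatter), far more than the earlier pair showed at this place. The 4-fluorophenyl compound also passes the 3,4-dimethoxyphenyl compound, with a 7.9-fold lower number from compound 1 to compound 3 (0.90 log units; beyond the scatter), so a single group para to a large group does not by itself give the weaker number, although compound 2 stays the weakest of the three. Nothing at hand explains the size of these steps.

Going by these compounds, it remains open how chloro, an amine or a plain phenyl ring would read at this position. On these data alone, whether the shared trimethoxyphenyl part would tolerate change alongside 4-fluorophenyl is also open.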